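The source may report more compounds than this note shows. Statements on the series, on what has been measured and on what is new or still open speak of the compounds shown alone.

Of the compounds shown here, three built on a shared core have been tested in a functional assay on C6 cells (Rattus norvegicus) for cytotoxicity, read by MTT assay, with a stated time of 24 h, tested at 100 ug/mL; on this read-out lower numbers stand for a stronger effect and higher numbers for a weaker effect at the one concentration tested. Compound 1 `Cc1ccc(-c2cs/c(=N/NC(=O)CSc3nnnn3-c3ccccc3)n2-c2ccccc2)cc1` gives 28.5%, the lowest of the three numbers. Compound 2 `Cc1nnc(SCC(=O)N/N=c2/scc(-c3ccc(F)cc3)n2-c2ccccc2)s1` gives 34.9%, which lies within the scatter of compound 1, while compound 3 `COc1ccc(-c2cs/c(=N/NC(=O)CSc3ncccn3)n2-c2ccccc2)cc1` gives 51.5%, a number beyond the scatter from compound 1. Compound 4 `O=C(CSc1nnnn1-c1ccccc1)N/N=c1/scc(-c2ccc(Cl)cc2)n1-c1ccccc1` has not yet been measured; it differs from compound 1 by chloro in place of methyl on an aromatic carbon. Within the data shown here, no measured pair differs in just this way, so the data offer no direct guide to the size of this step. The step of a number 1.5 percentage points higher from compound 1 to compound 4 (within the scatter) is therefore expected to be small, no larger than the scatter in either direction. On this basis compound 4 is estimated at 30%, expected to fall between 18% and 45%.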

Compound 4, a percentage reported as activity, at one concentration (the size of the read-out at that concentration, not a potency): 54.3%
Compound 4: middle estimate off by 24.3 percentage points, on the low side; measured number outside the range, above it.
By their numbers in this assay, from the lowest: compounds 1 and 2 (each within the scatter of the next); then compounds 3 and 4 (each within the scatter of the next).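

In this assay, chloro in place of methyl on the aromatic carbon para to a large group gives a number 25.8 percentage points higher from compound 1 to compound 4 (beyond the scatter) and the effect at the one concentration tested is weaker. Among these compounds, this is the first pair to differ in one place, and it shows that this position is sensitive to a change of a single heavy atom. No measurement at hand explains the step. From the compounds shown here alone, how an amine or a carboxylic acid at this position would read stays open. So does whether the 4-methylphenyl to 4-chlorophenyl change has a similar effect when other parts of the compound differ.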